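A few compounds are considered here, and "the series" means these few. Any claim that something is new, unique, unknown or untested is made for them only; others in the source may bear on it.

Compound 1, `COc1ccc(C2=NN(C(=O)CO[N+](=O)[O-])C(c3ccco3)C2)cc1OC`, was tested in a functional assay on the whole organism (strain albino) for inhibition, with Rattus norvegicus as the target, read by paw edema, with stated times of 30 min and 2 h, at a dose of 100 mg/kg by the oral route (a higher number here means more inhibition at the dose given (going by the name of the read-out), a lower number less inhibition), and gave 37%. Compound 2, `COc1ccc(C2CC(c3ccc(OC)c(OC)c3)=NN2C(=O)CO[N+](=O)[O-])c(OC)c1`, carries 2,4-dimethoxyphenyl in place of furan-2-yl on a saturated ring carbon and in this assay compound 2 gives 48%, so that a number 11 percentage points higher from compound 1 to compound 2 (beyond the scatter). Compound 3, `COc1ccc(C2=NN(C(=O)C(C)O[N+](=O)[O-])C(c3ccco3)C2)cc1OC`, differs from compound 1 by methyl in place of hydrogen on a saturated chain carbon bound to a carbonyl carbon and an oxygen on an unsaturated carbon; in this assay compound 3 gives 39%, and a number 2 percentage points higher from compound 1 to compound 3 (within the scatter). The two cores, that of compound 1 and that of compound 3, are thus told apart only by that one difference.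

Compound 4, `COc1ccc(C2CC(c3ccc(OC)c(OC)c3)=NN2C(=O)C(C)O[N+](=O)[O-])c(OC)c1`, is not yet measured. It stands to compound 3 as compound 2 stands to compound 1: 2,4-dimethoxyphenyl in place of furan-2-yl on a saturated ring carbon. The surroundings of the place are not described in the same words, since in the pair of compound 1 and compound 2 the ring atom two bonds away bears a ((nitrooxy)methyl)carbonyl group (7 heavy atoms), while in the pair of compound 3 and compound 4 it bears a group of 8 heavy atoms; the change is therefore the same kind of change, not the same change. Within the data shown here, the only measured instance of it is a number 11 percentage points higher from compound 1 to compound 2 (beyond the scatter), a modest rise. Because a number 2 percentage points higher from compound 1 to compound 3 (within the scatter) lies within the scatter, the core of compound 3 is expected to behave much like that of compound 1, and the step from compound 3 to compound 4 in this assay is expected to be about a number 10 percentage points higher from compound 3 to compound 4 (within the scatter). Compound 4 is therefore estimated to give about 49%, most likely between 37% and 61%.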

Compound 4, a percentage reported as inhibition, in the whole organism at one dose (the size of the read-out at that dose, not a potency): 61%
Compound 4: middle estimate off by 12 percentage points, on the low side, within the range that was stated.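

In this assay, 2,4-dimethoxyphenyl in place of furan-2-yl on a saturated ring carbon gives a step of a number 22 percentage points higher from compound 3 to compound 4 (beyond the scatter), so the rise seen on the core of compound 1 also appears on the core of compound 3, and the two steps agree as far as the scatter can tell: the same change on two cores in this assay, a number 11 percentage points higher (beyond the scatter) from compound 1 to compound 2 and a number 22 percentage points higher (beyond the scatter) from compound 3 to compound 4, 11 percentage points apart, within the scatter of two such steps. Methyl in place of hydrogen on the saturated chain carbon gives a number 13 percentage points higher from compound 2 to compound 4 (beyond the scatter), a step beyond the scatter where the earlier one was not, yet these two steps cannot be told apart either: the same change on two cores in this assay, a number 2 percentage points higher (within the scatter) from compound 1 to compound 3 and a number 13 percentage points higher (beyond the scatter) from compound 2 to compound 4, 11 percentage points apart, within the scatter of two such steps. This shows that both changes can be carried between these cores without a measurable loss of their effect, but it does not show that either change acts more strongly on one core than on the other, and each comparison rests on a single pair of steps.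

The compounds shown leave open how the read-out would respond to other groups on the saturated ring carbon, such as an unsubstituted phenyl or a pyridine ring, or to ethyl in place of methyl on the chain. They also leave open what happens when the nitrooxy group gives way to a hydroxyl group, and whether the steps hold at other doses.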